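The source may hold more compounds than are shown below. What is called first, only, known or untested is meant among the compounds shown, and "the series" means these compounds.

Compound 3 `CCCCCCCCCCCCOC(=O)CCC(=O)N1CCN(CCCOc2cc3c(Nc4ccc(F)c(Cl)c4)ncnc3cc2OC)CC1` gives 95.5% in a functional assay on A549 cells (Homo sapiens) for cytotoxicity, read by MTT assay, with a stated time of 24 h, tested at 10 uM (a higher number here means a weaker effect of the compound at the concentration tested, a lower number a stronger effect), the second highest of the three numbers measured, though none of the three stands apart from the others beyond the scatter. Compound 2 `CCCCCCCCCCOC(=O)CCC(=O)N1CCN(CCCOc2cc3c(Nc4ccc(F)c(Cl)c4)ncnc3cc2OC)CC1` gives 95.7% in this assay, and compound 1 `CCCCCCCOC(=O)CCC(=O)N1CCN(CCCOc2cc3c(Nc4ccc(F)c(Cl)c4)ncnc3cc2OC)CC1` gives 89.1%. The steps of a number 6.6 percentage points higher from compound 1 to compound 2 (within the scatter), a number 6.4 percentage points higher from compound 1 to compound 3 (within the scatter) and a number 0.2 percentage points lower from compound 2 to compound 3 (within the scatter) all stayed within the scatter. Compound 4 `CCCCCCCCCCCCCOC(=O)CCC(=O)N1CCN(CCCOc2cc3c(Nc4ccc(F)c(Cl)c4)ncnc3cc2OC)CC1` differs from compound 3 by methyl in place of hydrogen on a saturated chain carbon, ten or more bonds along the chain from an oxygen next to a carbonyl group. The step bearing most directly on this change is a number 0.2 percentage points lower from compound 2 to compound 3 (within the scatter), which also extended the chain far from the carbonyl and showed nothing beyond the scatter. No step beyond the scatter is therefore expected in this assay. Compound 4 is expected to give 95.5%, between 87% and 100%, an expected step of no change at the digits printed from compound 3 to compound 4 (within the scatter).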

Compound 4, a percentage reported as activity, at one concentration (the size of the read-out at that concentration, not a potency): 93.7%
Compound 4: middle estimate off by 1.8 percentage points, on the high side, within the range that was stated.
By their numbers in this assay, from the lowest: compounds 1, 4, 3 and 2 (each within the scatter of the next).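

Adding methyl in place of hydrogen on a saturated chain carbon gives (a number 1.8 percentage points lower from compound 3 to compound 4 (within the scatter)) in this assay. Among the compounds shown here, the further comparisons give (a number 2 percentage points lower from compound 2 to compound 4 (within the scatter)) and (a number 4.6 percentage points higher from compound 1 to compound 4 (within the scatter)), so with a fourth compound, still no step from lengthening this chain lies beyond the scatter. No evidence is available on why these numbers stay so close. As far as these compounds go, whether a longer chain, an amine or a carboxylic acid at the end of the chain would give a step beyond the scatter stays open.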